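This account rests on a few compounds, and the source may have more. Where it says the series, first, only, none or still open, it means among the compounds named here.

Compound 1 `C#CCSc1nc(NCCC#N)c2ccncc2n1`: > 80000 nM (a limit of the assay, not a number)
Compound 2 `C#CCSc1nc(Nc2cccc(Cl)c2)c2ccncc2n1`: 1090 nM
Compound 3 `C#CCSc1nc(Nc2ccc(Br)cc2)c2ccncc2n1`: 56200 nM

Going by the values given here, in a functional assay on HepG2 cells (Homo sapiens) for inhibition, read by MTT assay, with a stated time of 72 h (a lower number here means a stronger inhibitor, a higher number a weaker inhibitor), compound 3 gives 56200 nM, the higher of the two actual numbers so far. Compound 4 `C#CCSc1nc(Nc2cccc(O)c2)c2ccncc2n1` carries 3-hydroxyphenyl in place of 4-bromophenyl on a nitrogen on an aromatic ring.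

The closest guide is a 52-fold higher number from compound 2 to compound 3 (1.71 log units; beyond the scatter), a large step from a swap at the same place. Among the compounds with values here, compound 4 shares the 3 in its group's name with compound 2, but not the chlorine, and no compound with a 3-hydroxyphenyl group has been measured yet. The large at least 73-fold lower number from compound 1 to compound 2 (1.86 log units; beyond the scatter) also shows that this place can matter greatly, while an at least 1.4-fold lower number from compound 1 to compound 3 (0.15 log units; that floor lies within the scatter) has a floor within the scatter and says little.

Only part of the gap between compound 3 and compound 2 is therefore expected to be recovered. The expected change is a 5.6-fold lower number from compound 3 to compound 4 (0.75 log units; beyond the scatter), towards a lower number. For compound 4 the estimate is 10000 nM, with an expected range from 2000 nM to 60000 nM.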

Compound 4, half-maximal inhibitory concentration: 29500 nM
Compound 4: the middle estimate sits 3.0-fold (0.47 log units) below what was measured; low and high end bracket the measured number.
By their numbers in this assay, from the lowest: compound 2; then compounds 4 and 3 (each within the scatter of the next). At a limit, above all of these: compound 1.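

Hydroxy in place of chloro on the same ring gives a 27-fold higher number from compound 2 to compound 4 (1.43 log units; beyond the scatter), so in this assay the 3-substituted phenyl ring alone does not match compound 2; the group it carries matters too. The swap from 4-bromophenyl to 3-hydroxyphenyl gives a 1.9-fold lower number from compound 3 to compound 4 (0.28 log units; within the scatter), which leaves these two compounds indistinguishable, with compound 2 alone well apart from both. Compound 1 stands at a limit of the assay, not a number, so an at least 2.7-fold lower number from compound 1 to compound 4 (0.43 log units; beyond the scatter) gives only a floor for the gain from the 3-hydroxyphenyl group over the 2-cyanoethyl chain: the limit of > 80000 nM in this assay, at which 1 of the 4 values shown sits.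

Still open, going by these compounds, is whether chlorine itself is needed, which a 3-fluorophenyl or 3-methoxyphenyl group on the same nitrogen would test. A 4-chlorophenyl group would also show whether the large gap between the two halogen compounds follows the halogen or its place on the ring.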